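The source may report more compounds than this note shows. Statements on the series, on what has been measured and on what is new or still open speak of the compounds shown alone.

This study concerns a small set of peptide-like compounds that share one core and differ in two places. Compound 1 `CC(C)C[C@H](NC(=O)OCC1CCC(F)(F)CC1)C(=O)N[C@H](C=O)C[C@@H]1CCNC1=O` and compound 2 `CC(C)C[C@H](NC(=O)OCC1CCC(F)(F)CC1)C(=O)N[C@@H](C[C@@H]1CCNC1=O)C(O)S(=O)(=O)O` carry a smaller carbamate group; in an ADME assay on HEK-293T cells (Homo sapiens) for cytotoxicity, with a stated time of 72 h (a higher number here means that more compound is tolerated, a lower number that less compound is tolerated), compound 1 gives "not determined" (no result reported); "not determined" (no result reported) (2 entries), and compound 2 likewise gives "not determined" (no result reported); "not determined" (no result reported) (2 entries). Compound 3 `CC(C)C[C@H](NC(=O)OC(Cc1ccccc1)C1CCC(F)(F)CC1)C(=O)N[C@H](C=O)C[C@@H]1CCNC1=O` carries a benzyl-bearing carbamate. In this assay compound 3 gives > 100000 nM, which is a limit of the assay rather than a number; this is the limit of > 100000 nM in this assay, at which 1 of the 3 values shown sits, so compound 3 stands at the top of what the assay can report, with no numbered value anywhere in the set.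

Compound 4 `CC(C)C[C@H](NC(=O)OC(Cc1ccccc1)C1CCC(F)(F)CC1)C(=O)N[C@@H](C[C@@H]1CCNC1=O)C(O)S(=O)(=O)O` is the next step from compound 3. The change is hydroxy(sulfo)methyl in place of formyl on a saturated chain carbon bound to an amide-type nitrogen and a saturated chain carbon. Among the compounds with values here, no measured step between compounds is available for comparison, so the expectation rests on compound 3 alone. The step of a number no higher from compound 3 to compound 4 (the limit leaves the size open) is expected to be none beyond the usual scatter, since compound 3 already sits at the limit > 100000 nM. Compound 4 is therefore estimated at 100000 nM, in a range from 50000 nM to 300000 nM, most likely reported again only as a limit.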

Compound 4, half-maximal cytotoxic concentration: > 100000 nM
Compound 4 ended at the assay's limit; the forecaster's own chance of this, stated with the estimate: 75%; the middle value lies on the limit itself.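

In this assay compound 3 gives > 100000 nM, which is a limit. Compound 4 gives > 100000 nM, also a limit, so no step can be read between compound 3 and compound 4. The compounds shown leave open whether hydroxy(sulfo)methyl in place of formyl changes how much compound is tolerated.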